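A few compounds are considered here, and "the series" means these few. Any claim that something is new, unique, unknown or untested is made for them only; others in the source may bear on it.

Measured so far:
- compound 1 `c1ccc(-c2cn3ccnc3c(-c3ccc4ncn(C5CCCCC5)c4c3)n2)cc1`: 67.1%
- compound 2 `c1ccc2c(-c3cn4ccnc4c(-c4ccc5ncn(C6CCCCC6)c5c4)n3)cccc2c1`: 38.9%
- compound 3 `CC(=O)c1ccc(-c2cn3ccnc3c(-c3ccc4ncn(C5CCCCC5)c4c3)n2)cc1`: 2.65%

In a functional assay on HL-60 cells (Homo sapiens) for inhibition, read by sulforhodamine B assay, with a stated time of 48 h, tested at 10 uM (a higher number here means more inhibition at the concentration tested (going by the name of the read-out), a lower number less inhibition), compound 3 stands lowest of the three, beyond the scatter from both others. The unmeasured compound 4 `Fc1ccccc1-c1cn2ccnc2c(-c2ccc3ncn(C4CCCCC4)c3c2)n1` differs from it by one change: 2-fluorophenyl in place of 4-acetylphenyl on an aromatic carbon. Going by the values given here, two measured steps bear on this. The acetyl addition, a number 64.5 percentage points lower from compound 1 to compound 3 (beyond the scatter), is large, so removing it should recover much of the inhibition seen for compound 1. The other change of the outer ring, a number 28.2 percentage points lower from compound 1 to compound 2 (beyond the scatter), was modest, showing that the outer ring alone can shift the number. Compound 4 is therefore expected to rise strongly, a number 52.4 percentage points higher from compound 3 to compound 4 (beyond the scatter), landing near compound 1 though perhaps somewhat short of it. The estimate for compound 4 is 55%, within 25% to 80%.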

Compound 4, a percentage reported as inhibition, at one concentration (the size of the read-out at that concentration, not a potency): 9.3%
Beside the measured number, compound 4's estimate is 45.7 percentage points above it; the measured number lies below the stated range.
By their numbers in this assay, from the lowest: compounds 3 and 4 (each within the scatter of the next); then compound 2; then compound 1.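

In this assay, 2-fluorophenyl in place of 4-acetylphenyl gives a number 6.7 percentage points higher from compound 3 to compound 4 (within the scatter), so a second, quite different group on the outer phenyl ring also fails to keep the inhibition of unsubstituted phenyl. Even fluoro in place of hydrogen gives a number 57.8 percentage points lower from compound 1 to compound 4 (beyond the scatter), and 2-fluorophenyl in place of naphthalen-1-yl gives a number 29.6 percentage points lower from compound 2 to compound 4 (beyond the scatter), so the bulkier ring system retains more inhibition than either substituted phenyl. Nothing available explains these drops. On these data alone, whether an amine or a methoxy group on that ring would retain the inhibition of compound 1 remains open. So does whether moving a group around that ring changes the result.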